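The source may report more compounds than this note shows. Statements on the series, on what has been measured and on what is new or still open speak of the compounds shown alone.

Among the measured compounds shown here, in a functional assay on PC-3 cells (Homo sapiens) for inhibition, read by sulforhodamine B assay, with a stated time of 48 h, tested at 50 uM (on this read-out lower numbers stand for less inhibition of growth and higher numbers for more inhibition of growth at the one concentration tested), compound 1 (`COc1cc(/C=C/C(=O)/C=C/c2cc(OC)c(OC)c(OC)c2)ccc1OCc1cn(CCOc2cc(=O)oc3ccccc23)nn1`) gives 22% and this is the only number available for the series. Compound 2 (`COc1cc(/C=C/C(=O)/C=C/c2cccs2)ccc1OCc1cn(CCCCOc2cc(=O)oc3ccccc23)nn1`) gives "not active" (no number reported) in this assay and so offers no figure for comparison. Compound 3 (`COc1cc(/C=C/C(=O)/C=C/c2cc(OC)c(OC)c(OC)c2)ccc1OCc1cn(CCCCCOc2cc(=O)oc3ccccc23)nn1`) gives "not active" (no number reported) in this assay and offers none either. Compound 1 therefore stands alone on the numerical scale, with no measured neighbour to rank it against.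

Compound 4 (`COc1ccccc1/C=C/C(=O)/C=C/c1ccc(OCc2cn(CCOc3cc(=O)oc4ccccc34)nn2)c(OC)c1`) has yet to be measured, and its difference from compound 1 (2-methoxyphenyl in place of 3,4,5-trimethoxyphenyl on a double-bonded chain carbon bound to a double-bonded chain carbon) is 2-methoxyphenyl in place of 3,4,5-trimethoxyphenyl on a double-bonded chain carbon bound to a double-bonded chain carbon. For the measured compounds named here, no measured pair differs in one place, so the data give no size for such a change. In this assay no step beyond the scatter is expected, in either direction. The estimated step of a number 4 percentage points lower from compound 1 to compound 4 (within the scatter) is expected to remain within ordinary scatter. For compound 4 the expected value is 18% within an estimated range of 3% to 38% on repeated measurement.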

Compound 4, percent growth inhibition at one concentration: 11%
Compound 4: the middle estimate sits 7 percentage points above what was measured; the measured number falls inside the stated range.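

In this assay, placing 2-methoxyphenyl in place of 3,4,5-trimethoxyphenyl on a double-bonded chain carbon bound to a double-bonded chain carbon produces a number 11 percentage points lower from compound 1 to compound 4 (beyond the scatter) and so gives the series its first measured size for a change in one place. The step is modest but beyond the scatter, which shows that growth inhibition at this single concentration responds to the group at this place, at least in this one pair. Nothing at hand accounts for the direction or size of this step.

The compounds shown leave open whether the same exchange would give a similar step on a different chain, since compound 2 and compound 3 offer no number. They also leave open how a phenyl group carrying an amine or a carboxylic acid would read at this place.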